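The source may report more compounds than this note shows. Statements on the series, on what has been measured and on what is new or still open speak of the compounds shown alone.

Working notes on the series. Compound 1 `C=C(Br)C(=O)Nc1cccc(-c2cn3nc(Cc4cccc(OC)c4)sc3n2)c1` gives 1100 nM in a functional assay on FM3A cells (Mus musculus) for inhibition, read by cell counting, with a stated time of 2 days; on this read-out higher numbers stand for weaker inhibition and lower numbers for stronger inhibition. Compound 2 `C=C(Br)C(=O)Nc1cccc(-c2cn3nc(-c4cccs4)sc3n2)c1` gives 370 nM in this assay. Compound 3 `C=C(Br)C(=O)Nc1cccc(-c2cn3nc(CCc4ccccc4)sc3n2)c1` gives 2600 nM in this assay, the highest number of the three: the step of a 2.4-fold higher number from compound 1 to compound 3 (0.37 log units; beyond the scatter) is modest, and the step of a 7.0-fold higher number from compound 2 to compound 3 (0.85 log units; beyond the scatter) is larger. Compound 4 `C=C(Br)C(=O)Nc1cccc(-c2cn3nc(-c4ccc(Cl)cc4)sc3n2)c1` has not been measured; it differs from compound 3 by 4-chlorophenyl in place of phenethyl on an aromatic carbon. The step that bears on this is a 7.0-fold higher number from compound 2 to compound 3 (0.85 log units; beyond the scatter), where phenethyl replaced a ring bound directly to the shared core; compound 4 returns to a directly bound ring, though a different one. A lower number in this assay is therefore expected for compound 4, of modest size, with the direction more secure than the size. Compound 4 is estimated at 500 nM in this assay, expected range 150 nM to 1600 nM. The expected step is a 5.2-fold lower number from compound 3 to compound 4 (0.72 log units; beyond the scatter).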

Compound 4, half-maximal inhibitory concentration: 2000 nM
The estimate for compound 4 lay 4.0-fold (0.60 log units) below the measured number, outside the stated range (above it).
By their numbers in this assay, from the lowest: compound 2; then compounds 1, 4 and 3 (each within the scatter of the next, the first and the last beyond it).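

In this assay, a directly bound ring at this position does not by itself give the lower number: a 1.3-fold lower number from compound 3 to compound 4 (0.11 log units; within the scatter) stays within the scatter, and a 1.8-fold higher number from compound 1 to compound 4 (0.26 log units; within the scatter) also stays within it, so 4-chlorophenyl is not told apart from phenethyl or from 3-methoxybenzyl here. The identity of the directly bound ring matters, since a 5.4-fold higher number from compound 2 to compound 4 (0.73 log units; beyond the scatter) lies beyond the scatter. No measurement at hand accounts for this gap between thiophen-2-yl and 4-chlorophenyl.

Open, on these data alone, is whether the gap follows the chlorine or the ring itself, which plain phenyl would separate. Also open, as far as these compounds go, is where a directly bound ring carrying an amine or a carboxylic acid would fall.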